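This account rests on a few compounds, and the source may have more. Where it says the series, first, only, none or still open, it means among the compounds named here.

Measured so far:
Compound 1, `N=C(N)NCCC[C@H](NC(=O)CN(c1nc(Cl)nc2[nH]cnc12)C1CC1)C(=O)O`: 18.4%
Compound 2, `NCCCC[C@H](NC(=O)CN(c1nc(Cl)nc2[nH]cnc12)C1CC1)C(=O)OCc1ccccc1`: 25.4%

Among the measured compounds shown here, in a functional assay on the whole organism (Tail, strain ICR) with Mus musculus as the target, in the tail flick test, with a stated time of 90 min, at a dose of 12.5 umol/kg by the oral route (a higher number here means a stronger effect of the compound at the dose given, a lower number a weaker effect), compound 2 stands at the top of the two numbers so far, yet compound 1 gives 18.4%, a gap that lies within the scatter, so the two cannot be told apart. Compound 3, `NCCCC[C@H](NC(=O)CN(c1nc(Cl)nc2[nH]cnc12)C1CC1)C(=O)O`, is not yet measured. It differs from compound 2 by hydrogen in place of benzyl on an oxygen next to a carbonyl group. For the measured compounds named here, no step of this kind between measured compounds is known, so its direction is open; a small step, or none beyond the scatter, seems most likely. Compound 3 is expected to give 20%, between 5% and 38%, meaning an expected step of a number 5.4 percentage points lower from compound 2 to compound 3 (within the scatter).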

Compound 3, a percentage reported as activity, at one dose (the size of the read-out at that dose, not a potency): 22%
Compound 3: the middle estimate sits 2 percentage points below what was measured; the measured number falls inside the stated range.
By their numbers in this assay, from the lowest: compounds 1, 3 and 2 (each within the scatter of the next).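

In this assay, hydrogen in place of benzyl on an oxygen next to a carbonyl group gives a number 3.4 percentage points lower from compound 2 to compound 3 (within the scatter), so the benzyl ester and the free carboxy form cannot be told apart at this position. The same holds on the saturated chain carbon, where a group of 2 heavy atoms in place of a group of 4 gives a number 3.6 percentage points higher from compound 1 to compound 3 (within the scatter). No measurement here offers an explanation for either result. Going by these compounds, whether a methyl ester on that oxygen, or a longer chain ending in an amine, would give a step beyond the scatter stays open.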